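Sulfamoyl for chloro on the aniline ring of compound 1

The source may report more compounds than this note shows. Statements on the series, on what has been measured and on what is new or still open speak of the compounds shown alone.

Compound 1 `CC1(C)C[C@H](O)C[C@](C)(CNc2cccc(Cl)c2)C1` is the parent of this pair. Among the compounds with values here, in an ADME assay on MDCK cells (Canis lupus familiaris) for cytotoxicity, read by MTT assay, with a stated time of 3 days (a lower number here means that less compound is tolerated, a higher number that more compound is tolerated), compound 1 gives 9700 nM, which is the highest of the two numbers known so far. Compound 2 `CC1(C)C[C@H](O)C[C@](C)(CNc2cc(F)cc(Cl)c2)C1` differs from it only by fluoro in place of hydrogen on the aromatic ring and gives 4400 nM in this assay; the change is a 2.2-fold lower number from compound 1 to compound 2 (0.34 log units; beyond the scatter), a modest step beyond the scatter.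

Compound 3 `CC1(C)C[C@H](O)C[C@](C)(CNc2cccc(S(N)(=O)=O)c2)C1` is not yet measured. It is reached from compound 1 by sulfamoyl in place of chloro on an aromatic carbon. Within the data shown here, no measured step removes or exchanges the chloro, so the one step on record, from compound 1 to compound 2, bears on this change only in that a single substituent alteration on this ring shifted this assay by a modest amount. The direction of the step to compound 3 is not fixed by the data, and the expectation is therefore a number near that of compound 1 with a wide range. Compound 3 is estimated at 12000 nM, between 4000 nM and 40000 nM, which corresponds to an expected step of a 1.2-fold higher number from compound 1 to compound 3 (0.09 log units; within the scatter).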

Compound 3, half-maximal cytotoxic concentration: > 100000 nM
Compound 3 was reported as a limit (the forecaster's own chance of this, stated with the estimate: 20%); middle value at least 8.3-fold (0.92 log units) from the limit.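

Within the data shown here, exchanging the chloro itself moves the reading much further than the one earlier change on this ring, and the opposite way (an at least 10-fold higher number from compound 1 to compound 3 (1.01 log units; beyond the scatter), against a 2.2-fold lower number from compound 1 to compound 2 (0.34 log units; beyond the scatter)). So the carbon that carries the chloro in compound 1 is a place where a single exchange can shift tolerance in MDCK cells strongly upward, something the fluoro step did not reveal. In this assay compound 3 gives > 100000 nM, which is a limit of the assay and not a number, so the size of the step is known only from one side: the limit of > 100000 nM in this assay, at which 1 of the 3 values shown sits.

The compounds shown leave open whether this shift belongs to the sulfamoyl group as a whole or simply to the loss of chloro, and an amine or a carboxylic acid on the same aromatic carbon would help to separate the two. Also open, on these data alone, is whether the lower number that came with fluoro in compound 2 would carry over to a ring bearing sulfamoyl in place of chloro, and whether a longer chain on the sulfamoyl nitrogen would keep the reading at the limit.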